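The source may hold more compounds than are shown below. What is called first, only, known or untested is meant among the compounds shown, and "the series" means these compounds.

In a functional assay on HeLa cells (Homo sapiens) for inhibition, read by MTT assay, with a stated time of 24 h (on this read-out lower numbers stand for stronger inhibition and higher numbers for weaker inhibition), compound 3 `CCOC(=O)C1=Cc2ccccc2OC1(OCc1cn(-c2ccc(F)c(Cl)c2)nn1)C(F)(F)F` gives 22700 nM, the lowest of the two numbers shown; its nearest neighbour, compound 1 `CCOC(=O)C1=Cc2ccccc2OC1(OCc1cn(CC(=O)Nc2ccc(OC)cc2)nn1)C(F)(F)F`, gives 31900 nM, a gap within the scatter. Compound 2 `CCOC(=O)C1=Cc2ccccc2OC1(OCc1cn(-c2ccccc2)nn1)C(F)(F)F` reaches only the limit of this assay, > 150000 nM. The step from compound 2 to compound 3 gave an at least 6.6-fold lower number from compound 2 to compound 3 (0.82 log units; beyond the scatter), the step from compound 1 to compound 2 gave an at least 4.7-fold higher number from compound 1 to compound 2 (0.67 log units; beyond the scatter), and the step from compound 1 to compound 3 gave a 1.4-fold lower number from compound 1 to compound 3 (0.15 log units; within the scatter). Compound 4 `CCOC(=O)C1=Cc2ccccc2OC1(OCc1cn(-c2ccc([N+](=O)[O-])cc2)nn1)C(F)(F)F` carries 4-nitrophenyl in place of 3-chloro-4-fluorophenyl on an aromatic nitrogen. Because the step from compound 2 to compound 3 gave an at least 6.6-fold lower number from compound 2 to compound 3 (0.82 log units; beyond the scatter) when a substituted phenyl replaced the bare one, a nitro-substituted phenyl is expected to stay close, with an expected step of a 1.1-fold higher number from compound 3 to compound 4 (0.04 log units; within the scatter). Compound 4 is therefore estimated at 25000 nM, within 8000 nM to 80000 nM.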

Compound 4, half-maximal inhibitory concentration: > 150000 nM
Compound 4: only a limit was reported; the forecaster's own chance of this, stated with the estimate: 15%; middle value at least 6.0-fold (0.77 log units) from the limit.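

In this assay, a substituent on the phenyl does not by itself bring the number down: the 4-nitrophenyl group gives an at least 6.6-fold higher number from compound 3 to compound 4 (0.82 log units; beyond the scatter), and also an at least 4.7-fold higher number from compound 1 to compound 4 (0.67 log units; beyond the scatter). The gain seen so far therefore holds for 3-chloro-4-fluorophenyl, not for substituted phenyl groups in general, with compound 4 as the case against. Compound 4 reports only a limit, as compound 2 does, so the step between them cannot be read: the limit of > 150000 nM in this assay, at which 2 of the 4 values shown sit.

As far as these compounds go, whether the chlorine or the fluorine alone would give the lower number stays open. So does what an amine in place of the nitro group would give.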